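One Substitution, Measured Once, Expected Again

The compounds below may be only part of what the source reports. "The series", "measured", "known", "first", "only" and "open" are said of these compounds alone.

Compound 1 `Cc1ccccc1NC1=C/C(=N/NC(N)=S)C(=O)N=C1Nc1ccccc1C` and compound 2 `NC(=S)N/N=C1/C=C(Nc2cccc(Cl)c2)C(Nc2cccc(Cl)c2)=NC1=O` are built on closely related cores; the difference between the two cores is not broken down here. In a functional assay on MCF7 cells (Homo sapiens) for antiproliferative activity, read by MTT assay, with a stated time of 72 h (on this read-out higher numbers stand for weaker inhibition and lower numbers for stronger inhibition), compound 1 gives 580 nM and compound 2 gives 630 nM, two numbers within the usual scatter of each other. Compound 3 `Cc1ccccc1NC1=C/C(=N/N=C(\N)SCc2ccccc2)C(=O)N=C1Nc1ccccc1C` arises from compound 1 by the change (a group of 11 heavy atoms (8 carbon, 2 nitrogen, 1 sulfur; one six-membered aromatic ring of carbon only) in place of a group of 4 heavy atoms (1 carbon, 2 nitrogen, 1 sulfur; no ring), on a double-bonded nitrogen), and in this assay compound 3 gives 16300 nM, a step of a 28-fold higher number from compound 1 to compound 3 (1.45 log units; beyond the scatter). Compound 4 `N/C(=N\N=C1\C=C(Nc2cccc(Cl)c2)C(Nc2cccc(Cl)c2)=NC1=O)SCc1ccccc1` is related to compound 2 by the same change, (a group of 11 heavy atoms (8 carbon, 2 nitrogen, 1 sulfur; one six-membered aromatic ring of carbon only) in place of a group of 4 heavy atoms (1 carbon, 2 nitrogen, 1 sulfur; no ring), on a double-bonded nitrogen), made at the same place. A similar step is expected, a 27-fold higher number from compound 2 to compound 4 (1.43 log units; beyond the scatter), because the same change once gave a 28-fold higher number from compound 1 to compound 3 (1.45 log units; beyond the scatter). In this assay compound 4 is therefore estimated at 17000 nM, most likely between 6000 nM and 50000 nM.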

Compound 4, half-maximal inhibitory concentration: 15200 nM
Compound 4: middle estimate off by 1.1-fold (0.05 log units), on the high side; the measured number falls inside the stated range.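

In this assay, putting the larger group with its six-membered aromatic ring in place of the smaller ringless group gives a 24-fold higher number from compound 2 to compound 4 (1.38 log units; beyond the scatter), so the weakening seen on one core appears again on the other. The two steps match in size: the same change on two cores in this assay, a 28-fold higher number (1.45 log units; beyond the scatter) from compound 1 to compound 3 and a 24-fold higher number (1.38 log units; beyond the scatter) from compound 2 to compound 4, 1.2-fold (0.07 log units) apart, within the scatter of two such steps. This shows that the change carried over between these two closely related cores in this one cell assay, but it does not show that it would carry over to other cores, and it does not explain why the number rises.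

Still open, on these data alone, is which part of the entering group goes with the weaker inhibition. An entering group with a methyl in place of the aromatic ring, or one bearing a carboxylic acid, might give a step of a different size.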